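The compounds below may be only part of what the source reports. "The series", "measured", "known", "first", "only" and "open" are said of these compounds alone.

Compound 1 `CCC(C(=O)N1CCN(c2ccc(Cl)cc2)CC1)N1C(=O)CCC1=O` stands lowest of the two numbers in a functional assay on the whole organism (strain Swiss) with Mus musculus as the target, in the maximal electroshock model, with a stated time of 0.25 h, at a dose of 300 mg/kg by the intraperitoneal route (a lower number here means a weaker effect, a higher number a stronger effect of the compound at the dose given), where compound 1 gives 0%. For the measured compounds named here, compound 2 `CC(C(=O)N1CCN(c2ccc(Cl)cc2)CC1)N1C(=O)CCC1=O` gives 100%, and the only measured step, a number 100 percentage points higher from compound 1 to compound 2 (beyond the scatter), concerns the saturated chain carbon rather than the 4-chlorophenyl group. Compound 3 `CCC(C(=O)N1CCN(c2ccccc2Cl)CC1)N1C(=O)CCC1=O` differs from compound 1 by 2-chlorophenyl in place of 4-chlorophenyl on an amine nitrogen in a ring. Going by the values given here, no measured step bears on this change, so its size in this assay is open. A step of a number 20 percentage points higher from compound 1 to compound 3 (beyond the scatter) is expected, small against the one measured. The estimate for compound 3 is 20%, with a range from 0% to 75%.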

Compound 3, a percentage reported as activity, at one dose (the size of the read-out at that dose, not a potency): 50%
For compound 3 the middle estimate is 30 percentage points below the measured one; measured number inside the range.
By their numbers in this assay, from the lowest: compound 1; then compound 3; then compound 2.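

Read in this assay with the chain unchanged, 2-chlorophenyl in place of 4-chlorophenyl gives a number 50 percentage points higher from compound 1 to compound 3 (beyond the scatter) with the same atoms. The chlorophenyl group on the amine nitrogen in a ring is therefore a second place in the core of compound 1 where the read-out responds, besides the saturated chain carbon. Nothing measured here accounts for this step.

Open, from the compounds shown here alone, is how a plain phenyl or a fluorophenyl group would read at this place. Also open, going by these compounds, is whether the same change holds on the shorter chain of compound 2.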